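This account rests on a few compounds, and the source may have more. Where it says the series, first, only, none or still open, it means among the compounds named here.

Compound 3 (`O=C1CC(c2nc(-c3cccc(F)c3)no2)CN1c1ccc(F)cc1`) gives 88 nM in an in vitro functional assay on HEK293-A cells for positive allosteric modulation of metabotropic glutamate receptor 5 (Homo sapiens), read by FLIPR and calcium flux (on this read-out higher numbers stand for an effect only at larger amounts of compound and lower numbers for an effect already at smaller amounts), the second highest of three numbers. Its nearest neighbour is compound 2 (`O=C1CC(c2nc(-c3ccccc3)no2)CN1c1ccc(F)cc1`), which gives 58 nM; the furthest is compound 1 (`Cc1ccc(N2CC(c3nc(-c4cccc(C(F)(F)F)c4)no3)CC2=O)cc1`), which gives 3400 nM. Compound 4 (`O=C1CC(c2nc(-c3cccc(C(F)(F)F)c3)no2)CN1c1ccc(F)cc1`) differs from compound 3 by trifluoromethyl in place of fluoro on an aromatic carbon. Within the data shown here, only one measured step involves this ring: a 1.5-fold higher number from compound 2 to compound 3 (0.18 log units; within the scatter). Among the measured compounds shown here, no measured step isolates the change from fluoro to trifluoromethyl; compound 1 carries a trifluoromethyl at the same place but also differs on the other ring, so its value and that of compound 3 can only be set side by side. Compound 4 is therefore expected to give a higher number, a 10-fold higher number from compound 3 to compound 4 (1.01 log units; beyond the scatter), an estimated 900 nM with a range from 250 nM to 3500 nM.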

Compound 4, half-maximal effective concentration: > 10000 nM
Compound 4: no number, only a limit; the forecaster's own chance of this, stated with the estimate: 5%; middle value at least 11-fold (1.04 log units) away from the limit.
By their numbers in this assay, from the lowest: compounds 2 and 3 (each within the scatter of the next); then compound 1. At a limit, above all of these: compound 4.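

In this assay compound 4 has only a limit and not a number, yet that limit shows this place tolerates far less change than the step from hydrogen to fluoro suggested. Trifluoromethyl in place of fluoro gives an at least 110-fold higher number from compound 3 to compound 4 (2.05 log units; beyond the scatter), and trifluoromethyl in place of hydrogen gives an at least 170-fold higher number from compound 2 to compound 4 (2.23 log units; beyond the scatter). With trifluoromethyl present, the other ring also counts: fluoro in place of methyl gives an at least 2.9-fold higher number from compound 1 to compound 4 (0.46 log units; beyond the scatter). On these data alone, what a nitrile or a methoxy at this place would give stays open, as does the true value of compound 4.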